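Swapping cyano for nitro on compound 2

The source may hold more compounds than are shown below. What is called first, only, known or untested is meant among the compounds shown, and "the series" means these compounds.

Measured so far in a functional assay on CWR22R cells (Homo sapiens) for antiproliferative activity, read by propidium iodide staining, with a stated time of 96 h; on this read-out higher numbers stand for weaker inhibition and lower numbers for stronger inhibition:
Compound 1 `CC(O)(CSc1ccc(S(F)(F)(F)(F)F)cc1)C(=O)Nc1ccc([N+](=O)[O-])c(C(F)(F)F)c1` gives 9200 nM
Compound 2 `CC(O)(CSc1cccc(S(F)(F)(F)(F)F)c1)C(=O)Nc1ccc(C#N)cc1C(F)(F)F` gives 21600 nM
Compound 3 `CC(O)(CSc1ccc(S(F)(F)(F)(F)F)cc1)C(=O)Nc1ccc([N+](=O)[O-])cc1C(F)(F)F` gives 13100 nM

In this assay compound 2 stands at 21600 nM on this small set. That number lies within the scatter of compound 3 and beyond the scatter of compound 1, whose number is the lower of that pair.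

The next compound to be tested is compound 4 `CC(O)(CSc1cccc(S(F)(F)(F)(F)F)c1)C(=O)Nc1ccc([N+](=O)[O-])cc1C(F)(F)F`. It takes compound 2 and puts nitro in place of cyano on an aromatic carbon. Going by the values given here, no measured pair in the set differs in one place only, so the size of this change has no direct precedent here. The nearest evidence is indirect. Compound 3 also carries nitro and gives 13100 nM in a range close to compound 2, and compound 1 also carries nitro and gives 9200 nM as well, yet both differ from compound 2 in more than one place. On that basis no shift beyond the scatter is expected. The expected 1.4-fold lower number from compound 2 to compound 4 (0.16 log units; within the scatter) stays within the scatter, with a slight lean toward a lower number. For compound 4 the estimated value is 15000 nM with an expected range from 7000 nM to 32000 nM on this read-out.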

Compound 4, half-maximal inhibitory concentration: 17500 nM
For compound 4 the middle estimate is 1.2-fold (0.07 log units) below the measured one, and the stated range covers the measured number.
By their numbers in this assay, from the lowest: compounds 1, 3, 4 and 2 (each within the scatter of the next, the first and the last beyond it).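

In this assay, the set now holds its first pair that differs in one place only, and a 1.2-fold lower number from compound 2 to compound 4 (0.09 log units; within the scatter), with nitro in place of cyano on an aromatic carbon, stays within the scatter. The earlier compounds shown here could not show this, as each carrying nitro differs from compound 2 in more than one place. It shows that, with the rest of compound 2 held fixed, this read-out does not separate cyano from nitro at this position, meta to a trifluoromethyl group and para to a large group, and no measurement available here accounts for that result.

This single pair leaves open whether an amine, a carboxylic acid or a plain hydrogen on the same aromatic carbon would also stay within the scatter or would move the number beyond it. It also leaves open whether cyano and nitro would still read alike if the trifluoromethyl group gave way to a chlorine atom or a longer chain.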